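Cyclohexyl in place of 4-fluorophenyl: what to expect

The source may report more compounds than this note shows. Statements on the series, on what has been measured and on what is new or still open speak of the compounds shown alone.

Within the data shown here, compound 1 `CC(C)c1onc(-c2c(Cl)cccc2Cl)c1COc1ccc(-c2nc3ccc(C(=O)O)cc3n2Cc2ccc(F)cc2)cc1` holds the highest of the three numbers so far: in an assay on isolated protein for agonist activity at Bile acid receptor (Homo sapiens), read by TR-FRET (on this read-out lower numbers stand for an effect already at smaller amounts and higher numbers for an effect only at larger amounts of compound), compound 1 gives 105 nM. Compound 2 `CCCn1c(-c2ccc(OCc3c(-c4c(Cl)cccc4Cl)noc3C(C)C)cc2)nc2ccc(C(=O)O)cc21` gives 96.4 nM in this assay, and compound 3 `CC(C)Cn1c(-c2ccc(OCc3c(-c4c(Cl)cccc4Cl)noc3C(C)C)cc2)nc2ccc(C(=O)O)cc21` gives 24.7 nM. The step of a 1.1-fold lower number from compound 1 to compound 2 (0.04 log units; within the scatter) stays within the scatter, whereas a 4.3-fold lower number from compound 1 to compound 3 (0.63 log units; beyond the scatter) and a 3.9-fold lower number from compound 2 to compound 3 (0.59 log units; beyond the scatter) are both modest and beyond it. Compound 4 `CC(C)c1onc(-c2c(Cl)cccc2Cl)c1COc1ccc(-c2nc3ccc(C(=O)O)cc3n2CC2CCCCC2)cc1` differs from compound 1 by cyclohexyl in place of 4-fluorophenyl on a saturated chain carbon bound to an aromatic nitrogen. The steps from compound 1 to compound 2 and to compound 3 bear on this change, and the larger saturated group gave the lower number. A modest lowering beyond the scatter is therefore expected for compound 4, about a 2.6-fold lower number from compound 1 to compound 4 (0.42 log units; beyond the scatter). Compound 4 is estimated at 40 nM in this assay, with a range from 15 nM to 120 nM.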

Compound 4, half-maximal effective concentration: 19.9 nM
The estimate for compound 4 lay 2.0-fold (0.30 log units) above the measured number; the range from low to high includes it.
By their numbers in this assay, from the lowest: compounds 4 and 3 (each within the scatter of the next); then compounds 2 and 1 (each within the scatter of the next).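

The change from 4-fluorobenzyl to cyclohexylmethyl gives a 5.3-fold lower number from compound 1 to compound 4 (0.72 log units; beyond the scatter) in this assay and so shows that a six-membered ring at this place need not be aromatic. Against the open-chain groups, cyclohexyl gives a 1.2-fold lower number from compound 3 to compound 4 (0.09 log units; within the scatter) and a 4.8-fold lower number from compound 2 to compound 4 (0.69 log units; beyond the scatter) so it stands level with isopropyl and apart from ethyl. Nothing available explains these steps. From the compounds shown here alone, whether cyclopentyl, a longer chain or an amine on this carbon would hold the number as low remains open.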